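A Methyl Added Where Three Close Binders Already Sit

A few compounds are considered here, and "the series" means these few. Any claim that something is new, unique, unknown or untested is made for them only; others in the source may bear on it.

Three compounds were measured in an assay on isolated protein for binding affinity to Apoptosis regulator Bcl-2 (Homo sapiens), read by surface plasmon resonance; a higher number here means weaker binding, a lower number tighter binding. Compound 1 `CN(C)CC[C@H](CSc1ccccc1)Nc1ccc(S(=O)(=O)Nc2nnc3cc(N4CCN(Cc5ccccc5-c5ccc(Cl)cc5)CC4)cnn23)cc1[N+](=O)[O-]` gives 8 nM, compound 2 `CN(C)CC[C@H](CSc1ccccc1)Nc1ccc(S(=O)(=O)Nc2nnc3n2CCN(C2CCN(Cc4ccccc4-c4ccc(Cl)cc4)CC2)CC3)cc1S(=O)(=O)C(F)(F)F` gives 5 nM, and compound 3 `CN(C)CC[C@H](CSc1ccccc1)Nc1ccc(S(=O)(=O)Nc2ncnc3c2CCN(C2CCN(Cc4ccccc4-c4ccc(Cl)cc4)CC2)C3)cc1S(=O)(=O)C(F)(F)F` gives 7 nM. Compound 3 holds the second highest of these three numbers, yet its gaps to compound 1 and to compound 2 both lie within the scatter of repeated measurement, so the three cannot be ordered. Compound 4 `CC(c1ccccc1-c1ccc(Cl)cc1)N1CCC(N2CCc3c(ncnc3NS(=O)(=O)c3ccc(N[C@H](CCN(C)C)CSc4ccccc4)c(S(=O)(=O)C(F)(F)F)c3)C2)CC1` differs from compound 3 in one place: methyl in place of hydrogen on a saturated chain carbon bound to an amine nitrogen in a ring and an aromatic carbon, a methyl in place of hydrogen on a saturated chain carbon bound to an amine nitrogen in a ring and an aromatic carbon. Among the measured compounds shown here, no measured pair shows such a step, so a change of no change at the digits printed from compound 3 to compound 4 (within the scatter) in this assay is expected, within the scatter and without clear direction. Compound 4 is therefore estimated at 7 nM, between 3 nM and 16 nM.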

Compound 4, dissociation constant: 2 nM
Estimate against measurement, compound 4: 3.5-fold (0.54 log units) above; measured number outside the range, below it.
By their numbers in this assay, from the lowest: compound 4; then compounds 2, 3 and 1 (each within the scatter of the next).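

In this assay, the saturated chain carbon bound to an amine nitrogen in a ring and an aromatic carbon proves sensitive to substitution: methyl in place of hydrogen gives a 3.5-fold lower number from compound 3 to compound 4 (0.54 log units; beyond the scatter) and this step lies beyond the scatter. The earlier compounds shown here all carry hydrogen there, so they could not show this. No measurement shown here accounts for the tighter binding.

As far as these compounds go, whether an ethyl group at this carbon would tighten binding further or lose the gain remains open, as does the effect of a hydroxymethyl group.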